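This account rests on a few compounds, and the source may have more. Where it says the series, first, only, none or still open, it means among the compounds named here.

In a functional assay (aorta) with Rattus norvegicus as the target (on this read-out lower numbers stand for stronger inhibition and higher numbers for weaker inhibition), compound 1 (`CCCCN(CCCC)CCCOc1ccc(S(=O)(=O)c2c(C)cn3ccccc23)cc1`) gives 162 nM and compound 2 (`CCCN(CCC)CCCOc1ccc(S(=O)(=O)c2c(CC)cn3ccccc23)cc1`) gives 150 nM while compound 3 (`CCCCN(CCCC)CCCOc1ccc(S(=O)(=O)c2c(CC)cn3ccccc23)cc1`) gives 31.3 nM as the lowest of the three numbers. The next structure is compound 4 (`CCCCN(CCCC)CCCCCOc1ccc(S(=O)(=O)c2c(CC)cn3ccccc23)cc1`), which differs from compound 3 at the amine end of the chain: 2-(dibutylamino)ethyl in place of dibutylamino on a saturated chain carbon, three bonds along the chain from an oxygen on an aromatic ring with 2-(dibutylamino)ethyl in place of dibutylamino on a saturated chain carbon. For the measured compounds named here, no measured step makes this same change. The closest one is a 4.8-fold lower number from compound 2 to compound 3 (0.68 log units; beyond the scatter) for dibutylamino in place of dipropylamino at the same place, and the other is a 5.2-fold lower number from compound 1 to compound 3 (0.71 log units; beyond the scatter) for methyl in place of hydrogen on a saturated chain carbon bound to an aromatic carbon. Both are modest and beyond the scatter, but neither fixes a direction for this change, so no step beyond the scatter is expected in this assay and the range is kept wide. The expected change is a 1.3-fold higher number from compound 3 to compound 4 (0.11 log units; within the scatter) as an estimate only. For compound 4 the estimated value is 40 nM with an expected range from 12 nM to 130 nM in this read-out.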

Compound 4, half-maximal inhibitory concentration: 97.4 nM
Compound 4: middle estimate off by 2.4-fold (0.39 log units), on the low side, within the range that was stated.
By their numbers in this assay, from the lowest: compound 3; then compounds 4, 2 and 1 (each within the scatter of the next).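

In this assay, for the compounds shown here, the earlier steps showed only that dibutylamino gave a lower number than dipropylamino at this place. The larger 2-(dibutylamino)ethyl in place of dibutylamino now gives a 3.1-fold higher number from compound 3 to compound 4 (0.49 log units; beyond the scatter), so among these compounds a larger group at the amine end does not keep lowering the number. Set against dipropylamino, the same group gives a 1.5-fold lower number from compound 2 to compound 4 (0.19 log units; within the scatter), which lies within the scatter, so these two groups read alike at this place, and nothing given here explains this result.

Going by these compounds, what remains open is whether 2-(dipropylamino)ethyl would raise the number over dipropylamino in the same way. The compounds shown also leave open how a piperidine ring or a dipentylamino group would read at this place.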